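This account rests on a few compounds, and the source may have more. Where it says the series, first, only, none or still open, it means among the compounds named here.

Of the compounds shown here, two of a shared core have been measured so far. Compound 1, with the structure `O=C1C(Nc2ccc(Br)cc2)=CC(=O)c2c1nc1n2[C@H]2OC[C@@H](O)[C@H]2OC1`, carries a 4-bromophenyl group on its amine nitrogen. For the measured compounds named here, in a functional assay on MCF7 cells (Homo sapiens) for inhibition, read by sulforhodamine B assay (a lower number here means a stronger inhibitor, a higher number a weaker inhibitor), compound 1 gives 4330 nM, the only actual number among the values shown. Compound 2, with the structure `O=C1C=C(NC2CCCC2)C(=O)c2c1nc1n2[C@H]2OC[C@@H](O)[C@H]2OC1`, carries a cyclopentyl group on that nitrogen instead. In this assay compound 2 gives > 16000 nM, which is a limit of the assay rather than a number; this is the limit of > 16000 nM in this assay, at which 1 of the 2 values shown sits. Going by the values given here, no step between two measured compounds differing in a single place is available, so nothing measured tells how a change on this nitrogen shifts the read-out.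

Compound 3, with the structure `O=C1C(Nc2cccc(F)c2)=CC(=O)c2c1nc1n2[C@H]2OC[C@@H](O)[C@H]2OC1`, has not yet been measured. It differs from compound 1 in one place: 3-fluorophenyl in place of 4-bromophenyl on an amine nitrogen. Without a measured step of this kind to lean on, the expected step of a 1.4-fold higher number from compound 1 to compound 3 (0.14 log units; within the scatter) is taken as small, within or only slightly beyond the usual scatter. Compound 3 is therefore estimated to give about 6000 nM in this assay, with a likely span from 2500 nM to 15000 nM.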

Compound 3, half-maximal inhibitory concentration: > 4000 nM
Compound 3: a limit, no number (the forecaster's own chance of this, stated with the estimate: 15%); the middle value lies beyond the limit too.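

The step from compound 1 to compound 3 cannot be read, because compound 3 gives a limit of the assay and not a number: the limit of > 4000 nM in this assay, at which 1 of the 3 values shown sits.

The compounds shown leave open how far any change of the group on this amine nitrogen, such as 3-fluorophenyl in place of 4-bromophenyl, shifts the read-out in this assay.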